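The source may report more compounds than this note shows. Statements on the series, on what has been measured and on what is new or still open speak of the compounds shown alone.

Working notes on the series, read in a functional assay on ACHN cells (Homo sapiens); a higher number here means a weaker inhibitor of growth, a lower number a stronger inhibitor of growth. Going by the values given here, compound 1 `O=S(=O)(/C=C/c1ccccc1)Cc1ccc(Nc2ncnc3ccccc23)cc1` gives 58000 nM, and compound 2 `O=S(=O)(/C=C/c1ccc(F)cc1)Cc1ccc(Nc2ncnc3ccccc23)cc1` gives 10 nM, the lowest of the two numbers so far. Next is compound 3 `N#Cc1ccc(/C=C/S(=O)(=O)Cc2ccc(Nc3ncnc4ccccc34)cc2)cc1`, where cyano takes the place of fluoro on an aromatic carbon, para to a large group: cyano in place of fluoro on an aromatic carbon. Among the compounds with values here, one measured step bears on this change, fluoro in place of hydrogen on an aromatic carbon: a 5800-fold lower number from compound 1 to compound 2 (3.76 log units; beyond the scatter), large and beyond the scatter. Within the data shown here, it shows that one substituent can move the number strongly in this pair, but no measured pair compares fluoro with cyano, so the direction remains uncertain. Starting from the low end of the numbers, a moderate step to a higher number is expected, estimated as a 6.0-fold higher number from compound 2 to compound 3 (0.78 log units; beyond the scatter). For compound 3 the expected value is 60 nM, with an estimated range from 5 nM to 3000 nM.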

Compound 3, concentration for 50% growth inhibition: > 100000 nM
Compound 3 was reported as a limit (the forecaster's own chance of this, stated with the estimate: 5%); middle value at least 1600-fold (3.22 log units) from the limit.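

The step from fluoro to cyano, on an aromatic carbon para to a large group, gives an at least 10000-fold higher number from compound 2 to compound 3 (4.00 log units; beyond the scatter), so a low number here does not follow from simply having a substituent at this place. Cyano in place of hydrogen gives an at least 1.7-fold higher number from compound 1 to compound 3 (0.23 log units; that floor lies within the scatter), and since that floor lies within the scatter, no order can be stated for this pair. Compound 3 is reported as a limit and not as a number: the limit of > 100000 nM in this assay, at which 1 of the 3 values shown sits.

On these data alone, the true value of compound 3 remains open, so both new steps stand only as floors. Also open, as far as these compounds go, is whether the low number is particular to fluoro or extends to other groups at this place, such as chloro, methoxy or an amine.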